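Chloro for Fluoro, Carried Onto a Second Core

This account rests on a few compounds, and the source may have more. Where it says the series, first, only, none or still open, it means among the compounds named here.

Of the compounds shown here, three have so far been measured in a functional assay on B16-BL6 cells (Mus musculus) for cytotoxicity, read by MTT assay, with a stated time of 48 h; a lower number here means a stronger inhibitor, a higher number a weaker inhibitor. Compound 1 `CNC(=O)c1ccc(Sc2cccc(NC(=S)Nc3ccc(Cl)c(C(F)(F)F)c3)c2)nc1` gives 19800 nM, and compound 2 `CNC(=O)c1ccc(Sc2cccc(NC(=S)Nc3ccc(F)c(C(F)(F)F)c3)c2)nc1` gives 42400 nM. These two share one core and differ in a single place: chloro in place of fluoro on an aromatic carbon. That change produced a 2.1-fold lower number from compound 2 to compound 1 (0.33 log units; beyond the scatter). Compound 3 `CNC(=O)c1ccc(Sc2ccc(NC(=S)Nc3ccc(F)c(C(F)(F)F)c3)cc2)nc1` is built from the same atoms as compound 2 joined differently, and the difference between the two cores is not broken down here. In this assay compound 3 gives 29300 nM, a number that sits within the scatter of both compound 2 and compound 1.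

Compound 4 `CNC(=O)c1ccc(Sc2ccc(NC(=S)Nc3ccc(Cl)c(C(F)(F)F)c3)cc2)nc1` has not yet been measured. It stands to compound 3 as compound 1 stands to compound 2: chloro in place of fluoro on an aromatic carbon. The change occurs twice among these compounds, and the earlier instance is the only guide to its size. If that step carries over to the core of compound 3, the expected step is a 2.1-fold lower number from compound 3 to compound 4 (0.32 log units; beyond the scatter) in this assay, because the same change gave a 2.1-fold lower number from compound 2 to compound 1 (0.33 log units; beyond the scatter). Compound 4 is accordingly estimated at 14000 nM, with a likely range from 7000 nM to 30000 nM.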

Compound 4, half-maximal inhibitory concentration: 23500 nM
The estimate for compound 4 lay 1.7-fold (0.22 log units) below the measured number; measured number inside the range.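

On the second core, chloro in place of fluoro gave a 1.2-fold lower number from compound 3 to compound 4 (0.10 log units; within the scatter) in this assay. Set beside the earlier instance, the two steps cannot be told apart: the same change on two cores in this assay, a 2.1-fold lower number (0.33 log units; beyond the scatter) from compound 2 to compound 1 and a 1.2-fold lower number (0.10 log units; within the scatter) from compound 3 to compound 4, 1.7-fold (0.23 log units) apart, within the scatter of two such steps. This fits a change that carries from one core to the other, but it does not show that the step has the same size on both, and on the second core the step alone does not establish any difference between chloro and fluoro; two instances in a single assay are too few to fix its size.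

All the compounds shown keep the trifluoromethyl group and carry only fluoro or chloro at the place of change. Left open are how bromo, a nitrile or an amine at that place would compare on either core, and whether the pair of steps would look the same on any further core or in another assay.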